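A few compounds are considered here, and "the series" means these few. Any claim that something is new, unique, unknown or untested is made for them only; others in the source may bear on it.

Compound 1 `O[C@H]1CCCC[C@@H]1Nc1nc(-c2ccccc2)nc2c1nnn2Cc1ccccc1` and compound 2 `OCCCNc1nc(-c2ccccc2)nc2c1nnn2Cc1ccccc1F` share a core and were both tested in an assay on isolated protein for binding affinity to adenosine receptor A1 (Bos taurus); on this read-out higher numbers stand for weaker inhibition and lower numbers for stronger inhibition. In this assay compound 1 gives 10300000 nM, and compound 2 gives 3700000 nM. Of the two numbers, compound 1 stands at the higher one, and the gap to compound 2 lies beyond the usual scatter, so compound 1 is the weaker of the pair on this read-out.

Compound 3 `c1ccc(Cn2nnc3c(NC4CC4)nc(-c4ccccc4)nc32)cc1` has not yet been measured in this assay. It differs from compound 1 in one place: cyclopropyl in place of 2-hydroxycyclohexyl on a nitrogen on an aromatic ring. Among the compounds with values here, no measured pair in this set shows what such a change does, so the expected step rests only on the two numbers above and the nature of the change. Both measured compounds sit at very weak binding, and the account expects compound 3 to stay in that region, with a step from compound 1 to compound 3 of a 2.1-fold lower number from compound 1 to compound 3 (0.31 log units; beyond the scatter), which is an estimated change of modest size and uncertain direction. For compound 3 the estimate in this assay is 5000000 nM, with a range from 1000000 nM to 30000000 nM.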

Compound 3, inhibition constant: 11000000 nM
Compound 3: the middle estimate sits 2.2-fold (0.34 log units) below what was measured; measured number inside the range.
By their numbers in this assay, from the lowest: compound 2; then compounds 1 and 3 (each within the scatter of the next).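

Placing cyclopropyl in place of 2-hydroxycyclohexyl on a nitrogen on an aromatic ring gives, in this assay, a 1.1-fold higher number from compound 1 to compound 3 (0.03 log units; within the scatter), the first reading of an exchange at this position. The exchange removes a six-membered ring of carbon, its hydrogen-bond donor and acceptor, and both defined stereocentres, yet compound 1 and compound 3 remain within the scatter of each other, so at this very weak level of binding the read-out does not tell the two groups apart. Nothing measured here accounts for this match.

Within the data shown here, the single step cannot separate the part played by the ring from that played by the hydroxyl, and plain cyclohexyl on the same nitrogen would address that question directly. As far as these compounds go, it also remains open whether any other group at this position would leave this very weak region, such as a longer unbranched alkyl chain, a morpholine ring or a chain ending in a carboxylic acid.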